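Swapping the Diazepane for a Sulfonylpiperazine in Compound 4

A few compounds are considered here, and "the series" means these few. Any claim that something is new, unique, unknown or untested is made for them only; others in the source may bear on it.

In an assay for inhibition of mitogen-activated protein kinase kinase kinase 14 (Homo sapiens), read by luminescence and ADP-Glo, with a stated time of 120 min, in the presence of a further agent that is not named here (on this read-out lower numbers stand for stronger inhibition and higher numbers for weaker inhibition), three compounds built on one shared core have been measured:

compound 1 `CC(O)(C#Cc1ccc(N2CCCC2)c(Nc2ncnc3[nH]ccc23)c1)c1nccs1` gives 107 nM
compound 2 `CN1CCN(c2ccc(C#CC(C)(O)c3nccs3)cc2Nc2ncnc3[nH]ccc23)CC1` gives 78.3 nM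
compound 3 `CN1CCCN(c2ccc(C#CC(C)(O)c3nccs3)cc2Nc2ncnc3[nH]ccc23)CC1` gives 60.1 nM

The three numbers sit close together. The step of a 1.4-fold lower number from compound 1 to compound 2 (0.14 log units; within the scatter) and the step of a 1.8-fold lower number from compound 1 to compound 3 (0.25 log units; within the scatter) are both within the scatter, as is the step of a 1.3-fold lower number from compound 2 to compound 3 (0.11 log units; within the scatter). Compound 3 therefore carries the lowest of the three numbers, but on these data it cannot be told apart from compound 2 or compound 1.

Compound 4 `CCS(=O)(=O)N1CCN(c2ccc(C#CC(C)(O)c3nccs3)cc2Nc2ncnc3[nH]ccc23)CC1` has not yet been measured. It differs from compound 3 in one place: 4-(ethylsulfonyl)piperazin-1-yl in place of 4-methyl-1,4-diazepan-1-yl on an aromatic carbon. All three measured steps bear on this change, since each of them also exchanges the saturated amine ring on that same aromatic carbon, and none of them moved the number beyond the scatter. The new ring brings a sulfonyl group that none of the earlier three carries, so the measured steps do not cover it directly, but they give no ground to expect a large shift. Compound 4 is therefore expected to give about 85 nM, with a range from 30 nM to 250 nM. The expected step of a 1.4-fold higher number from compound 3 to compound 4 (0.15 log units; within the scatter) is estimated to stay within the scatter.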

Compound 4, half-maximal inhibitory concentration: 8.22 nM
Estimate against measurement, compound 4: 10-fold (1.01 log units) above, and the stated range ends above it.
By their numbers in this assay, from the lowest: compound 4; then compounds 3, 2 and 1 (each within the scatter of the next).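

In this assay, this position no longer looks indifferent to what it carries: 4-(ethylsulfonyl)piperazin-1-yl in place of 4-methyl-1,4-diazepan-1-yl gives a 7.3-fold lower number from compound 3 to compound 4 (0.86 log units; beyond the scatter), and in place of pyrrolidin-1-yl it gives a 13-fold lower number from compound 1 to compound 4 (1.11 log units; beyond the scatter). The most direct reading is a 9.5-fold lower number from compound 2 to compound 4 (0.98 log units; beyond the scatter), where the six-membered ring stays and only the group on its amine nitrogen changes, from methyl to ethylsulfonyl; the change of ring alone, from compound 2 to compound 3, stayed within the scatter, so on these compounds the step goes with the ethylsulfonyl group and not with ring size. The data shown offer no measurement that explains why the number falls.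

The compounds shown leave open whether the sulfonyl or the ethyl carries this step, a question that a methylsulfonyl, an acetyl or a plain ethyl on the same ring nitrogen would help to separate. Also open, going by these compounds, is whether ethylsulfonyl on the seven-membered ring of compound 3, or on a longer chain in its place, would give a step of the same size, since this result rests on compound 4 alone.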